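Amide-side substituent swap on a shared core: cytotoxicity

This account rests on a few compounds, and the source may have more. Where it says the series, first, only, none or still open, it means among the compounds named here.

Measured so far:
compound 1 `Cn1c(Cc2ccccc2C(F)(F)F)nc(C(=O)NCc2cccnc2)c(O)c1=O`
compound 2 `CC(c1ccccc1C(F)(F)F)c1nc(C(=O)NCc2ccccc2)c(O)c(=O)n1C`
compound 3 `CC(NC(=O)c1nc(Cc2ccccc2C(F)(F)F)n(C)c(=O)c1O)c1ccccc1`

In an ADME assay on HepG2 cells (Homo sapiens) for cytotoxicity, in the presence of a further agent that is not named here (a lower number here means a stronger inhibitor, a higher number a weaker inhibitor), compound 1 gives > 100000 nM, a limit of the assay and not a number. In this assay compound 2 gives > 100000 nM, again a limit. In this assay compound 3 gives > 100000 nM, also a limit. Compound 3 therefore stands at the edge of what this assay reports, alongside the other two measured compounds, as summarised by the limit of > 100000 nM in this assay, at which 3 of the 3 values shown sit. Among the measured compounds shown here, the one measured step touching the amide-type nitrogen, a step that the two limits leave unreadable from compound 1 to compound 3, is unreadable, since both of its ends are limits.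

Compound 4 `Cn1c(Cc2ccccc2C(F)(F)F)nc(C(=O)NCc2ccc(F)cc2)c(O)c1=O` differs from compound 3 by 4-fluorobenzyl in place of 1-phenylethyl on an amide-type nitrogen. Two different groups on that nitrogen, in compound 1 and compound 3, both leave the value at the limit, so no step beyond the scatter is expected here. Compound 4 is expected to give about 100000 nM in this assay, with a range from 50000 nM to 200000 nM. The step of a number no higher from compound 3 to compound 4 (the limit leaves the size open) is thus expected to be flat, most likely reported only as a limit again.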

Compound 4, half-maximal inhibitory concentration: > 100000 nM
Compound 4: no number, only a limit; the forecaster's own chance of this, stated with the estimate: 85%; the middle value sits exactly at the limit.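

Neither new step, from compound 1 or from compound 3 to compound 4, can be read, for both ends of each are limits. All the values shown sit at that one edge: the limit of > 100000 nM in this assay, at which 4 of the 4 values shown sit.

The compounds shown leave open whether any group on the amide-type nitrogen changes the value in this assay.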